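This account rests on a few compounds, and the source may have more. Where it says the series, first, only, none or still open, it means among the compounds named here.

Measured so far in a functional assay on the whole organism with Rattus norvegicus as the target, with a stated time of 4 h, at a dose of 40 mg/kg by the intraperitoneal route; on this read-out higher numbers stand for more inhibition at the one dose given (going by the name of the read-out) and lower numbers for less inhibition:
Compound 1, `Cc1nc2c(OCc3ccccc3)cccn2c1CC1=NCCN1`: 69%
Compound 2, `CCCCC(=O)OCc1c(C)nc2c(OCc3ccccc3)cccn12`: 45%

Among the measured compounds shown here, on these two numbers compound 2 stands lowest, and the only measured step, a number 24 percentage points lower from compound 1 to compound 2 (beyond the scatter), reaches beyond the scatter. Compound 3, `Cc1nc2c(OCc3ccccc3)cccn2c1COC(=O)c1cccnc1`, differs from compound 2 in one place: pyridin-3-yl in place of butyl on a carbonyl carbon. For the measured compounds named here, the measured step changed the group on the saturated chain carbon bound to an aromatic carbon, while the change to compound 3 sits on the carbonyl carbon within the ester that compound 2 already carries; no measured step therefore bears on it directly, and the data give no pull in either direction for this replacement. Compound 3 is accordingly expected to land near compound 2, with a step of no change at the digits printed from compound 2 to compound 3 (within the scatter) that should not exceed the scatter. The estimate for compound 3 in this assay is 45%, expected to fall between 25% and 65%.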

Compound 3, a percentage reported as inhibition, in the whole organism at one dose (the size of the read-out at that dose, not a potency): 87%
Beside the measured number, compound 3's estimate is 42 percentage points below it; the measured number lies above the stated range.
By their numbers in this assay, from the lowest: compound 2; then compound 1; then compound 3.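

In this assay, the group on the carbonyl carbon of the ester proves to weigh heavily: pyridin-3-yl in place of butyl gives a number 42 percentage points higher from compound 2 to compound 3 (beyond the scatter) in a single change. An ester on the saturated chain carbon bound to an aromatic carbon therefore does not by itself lower the number, since a number 24 percentage points lower from compound 1 to compound 2 (beyond the scatter) is now set against a number 18 percentage points higher from compound 1 to compound 3 (beyond the scatter) and the direction depends on what the ester carries. Nothing at hand explains why pyridin-3-yl reads so much higher than butyl.

The compounds shown leave open whether the ring nitrogen matters or an all-carbon phenyl on the carbonyl carbon would do the same. They also leave open how pyridin-2-yl, pyridin-4-yl or a longer chain would read in that place.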